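A few compounds are considered here, and "the series" means these few. Any claim that something is new, unique, unknown or untested is made for them only; others in the source may bear on it.

Going by the values given here, in a functional assay on A549 cells (Homo sapiens) for antiproliferative activity, read by MTT assay, with a stated time of 72 h (a lower number here means a stronger inhibitor, a higher number a weaker inhibitor), compound 2 `COc1ccc(-c2ncnn2-c2cc(OC)c(OC)c(OC)c2)cc1` gives 520 nM, the only true number in this small set. Compound 1 `COc1cc(-c2ncnn2-c2ccc(Cl)cc2Cl)cc(OC)c1OC` reads > 10000 nM, which is a limit of the assay and not a number. Compound 3 `COc1cc(-n2ncnc2-c2ccc(OC(C)C)cc2)cc(OC)c1OC` reads > 10000 nM, again a limit.

Compound 4 `COc1ccccc1-c1ncnn1-c1cc(OC)c(OC)c(OC)c1` is built from the same atoms as compound 2, joined differently: 2-methoxyphenyl in place of 4-methoxyphenyl on an aromatic carbon. It carries 2-methoxyphenyl in place of 4-methoxyphenyl on an aromatic carbon of the five-membered aromatic ring with 3 nitrogen.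

Among the compounds with values here, only one measured step touches this group: an at least 19-fold higher number from compound 2 to compound 3 (1.28 log units; beyond the scatter), with isopropyl in place of methyl on an oxygen on an aromatic ring. Within the data shown here, that step is large and lies beyond the scatter, but it is a different change from the one in compound 4, so it guides the direction more firmly than the size. On the strength of that single step, a smaller move toward a weaker inhibitor is expected in this assay. The estimated change is a 3.8-fold higher number from compound 2 to compound 4 (0.59 log units; beyond the scatter). For compound 4 the estimate is 2000 nM, with an expected range of 300 nM to 10000 nM.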

Compound 4, half-maximal inhibitory concentration: > 10000 nM
Compound 4 ended at the assay's limit (the forecaster's own chance of this, stated with the estimate: 25%); middle value at least 5.0-fold (0.69 log units) from the limit.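

In this assay, 2-methoxyphenyl in place of 4-methoxyphenyl gives an at least 19-fold higher number from compound 2 to compound 4 (1.28 log units; beyond the scatter), so a change in how the same atoms are joined is enough to lose the measured activity of compound 2. The earlier step altered the group on oxygen and added atoms, whereas this one adds none and moves only the methoxy group on the phenyl ring. The true size of the loss stays unknown, and the step gives only its lower bound: the limit of > 10000 nM in this assay, at which 3 of the 4 values shown sit.

The steps to compound 3 and compound 4 both end at that limit, so they cannot be ranked against each other. From the compounds shown here alone, whether an amine or a hydroxyl group in place of the methoxy group of compound 2 would hold the activity stays open.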